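Phenoxy variation on the shared core toward compound 4

This account rests on a few compounds, and the source may have more. Where it says the series, first, only, none or still open, it means among the compounds named here.

Compound 1 `Nc1cc(N)c2nc(-c3ccccc3)c(Oc3ccc(Cl)c(Cl)c3)nc2c1` is known in a functional assay on 786-0 cells (Homo sapiens) for inhibition, read by sulforhodamine B assay, with a stated time of 48 h (a lower number here means that less compound is tolerated, a higher number that more compound is tolerated), only as a limit, < 100000 nM. Compound 2 `Nc1cc(N)c2nc(-c3ccccc3)c(NCc3ccc(Cl)c(Cl)c3)nc2c1` gives 70800 nM in this assay. Compound 3 `CCOC(=O)[C@H](CCC(=O)O)NC(=O)c1ccc(Sc2nc3cc(N)cc(N)c3nc2-c2ccccc2)cc1` is likewise known only as a limit, < 100000 nM. Compound 1 thus stands at the limit of < 100000 nM in this assay, at which 2 of the 3 values shown sit, and no order among the three measured compounds can be read from this. Compound 4 `Nc1cc(N)c2nc(-c3ccccc3)c(Oc3ccc(F)cc3)nc2c1` has not been measured; it carries 4-fluorophenyl in place of 3,4-dichlorophenyl on an oxygen on an aromatic ring. Among the measured compounds shown here, no step between measured compounds differing in a single place is available, so the direction of this change rests on no measured precedent and no step beyond the scatter is anticipated. Compound 4 is expected in this assay at 70000 nM, between 30000 nM and 100000 nM. The estimated step is a step that the limit leaves unreadable from compound 1 to compound 4, within the scatter.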

Compound 4, concentration lethal to 50% of the cells: 75900 nM
Compound 4: the middle estimate sits 1.1-fold (0.04 log units) below what was measured; the range from low to high includes it.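

No step from compound 1 to compound 4 can be read in this assay, because compound 1 stands only as a limit: the limit of < 100000 nM in this assay, at which 2 of the 4 values shown sit.

The compounds shown leave open how 4-fluorophenyl and 3,4-dichlorophenyl compare on this oxygen.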